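The source may hold more compounds than are shown below. What is called first, only, known or untested is meant among the compounds shown, and "the series" means these compounds.

Compound 1 `CC(C)C(C)Nc1nc(O)c2cc(Cl)ccc2n1` — 16300 nM
Compound 2 `Oc1nc(NCC2CCCCC2)nc2ccc(Cl)cc12` — 2200 nM
Compound 3 `CC(C)C(C)Nc1nc(O)c2cc(I)ccc2n1` — 4100 nM

The three measured compounds were tested in a functional assay (aorta) for inhibition, with Rattus norvegicus as the target; on this read-out lower numbers stand for stronger inhibition and higher numbers for weaker inhibition. Compound 1 gives 16300 nM and compound 3 gives 4100 nM in this assay; the change between them, (iodo in place of chloro on an aromatic carbon), made a step of a 4.0-fold lower number from compound 1 to compound 3 (0.60 log units; beyond the scatter). Compound 2 gives 2200 nM, within the scatter of compound 3 and beyond it only against compound 1. The difference between the core of compound 2 and the core of compound 1 is not broken down here.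

Compound 4 `Oc1nc(NCC2CCCCC2)nc2ccc(I)cc12` is not yet measured. It differs from compound 2 by iodo in place of chloro on an aromatic carbon, the same change that turned compound 1 into compound 3, at the same place in the same words. In this assay the step from compound 2 to compound 4 is expected to be a 4.0-fold lower number from compound 2 to compound 4 (0.60 log units; beyond the scatter), resting on the single earlier example of this change, because a 4.0-fold lower number from compound 1 to compound 3 (0.60 log units; beyond the scatter) is all that is known of it and it occurs only twice among the compounds shown. Compound 4 is therefore estimated at 550 nM, somewhere between 250 nM and 1500 nM.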

Compound 4, half-maximal inhibitory concentration: 3900 nM
Beside the measured number, compound 4's estimate is 7.1-fold (0.85 log units) below it; the measured number lies above the stated range.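

In this assay, iodo in place of chloro on an aromatic carbon gave a 1.8-fold higher number from compound 2 to compound 4 (0.25 log units; within the scatter), so on the core of compound 2 this change produced no difference that can be told from the scatter. Set beside the earlier example, the result shows that the change did not carry over from one core to the other: the same change on two cores in this assay, a 4.0-fold lower number (0.60 log units; beyond the scatter) from compound 1 to compound 3 and a 1.8-fold higher number (0.25 log units; within the scatter) from compound 2 to compound 4, 7.0-fold (0.85 log units) apart, beyond the scatter of two such steps. The gain seen on the core of compound 1 therefore cannot be assumed on another core in this series, but two pairs do not show what in the two cores sets the steps apart, and they give no rule for any further core.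

The compounds shown leave open how bromo or fluoro on the same aromatic carbon would read on either core. They also leave open whether a core carrying a longer alkyl chain would follow the step seen on the core of compound 1 or the one seen on the core of compound 2.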